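The compounds below may be only part of what the source reports. "The series", "measured", "known", "first", "only" and "open" are said of these compounds alone.

Compound 3 `c1ccc(-c2cnccn2)c(NCC2=NCCN2)c1` holds the second highest of the three measured numbers in a functional assay for activation of Alpha-1A adrenergic receptor (Homo sapiens), read by calcium flux (on this read-out higher numbers stand for an effect only at larger amounts of compound and lower numbers for an effect already at smaller amounts), where compound 3 gives 4.57 nM. Its nearest neighbour is compound 1 `Cc1ccsc1-c1ccccc1NCC1=NCCN1`, which in this assay gives 0.851 nM; the furthest is compound 2 `Cc1nc(-c2ccccc2NCC2=NCCN2)no1`, which in this assay gives 724 nM. The step of a 5.4-fold higher number from compound 1 to compound 3 (0.73 log units; beyond the scatter) was modest, whereas an 850-fold higher number from compound 1 to compound 2 (2.93 log units; beyond the scatter) and a 160-fold lower number from compound 2 to compound 3 (2.20 log units; beyond the scatter) were large. Compound 4 `CCO/N=C(\C)c1ccccc1NCC1=NCCN1` differs from compound 3 by a group of 6 heavy atoms (4 carbon, 1 nitrogen, 1 oxygen; no ring) in place of a group of 6 heavy atoms (4 carbon, 2 nitrogen; one six-membered aromatic ring with 2 hetero atoms), on an aromatic carbon, sitting on an aromatic carbon of a six-membered aromatic ring of carbon only. All three measured steps exchange one aromatic ring for another at this position, and they show that the group placed there can move the number by anything from a modest to a large amount. For the measured compounds named here, in compound 4 an acyclic group enters instead of a ring, a change none of the measured steps covers, so the direction rests on the wide spread already seen. Compound 4 is therefore expected to show a 6.6-fold higher number from compound 3 to compound 4 (0.82 log units; beyond the scatter). The estimate for compound 4 in this assay is 30 nM, expected to lie between 3 nM and 300 nM.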

Compound 4, half-maximal effective concentration: 52.5 nM
For compound 4 the middle estimate is 1.8-fold (0.24 log units) below the measured one; low and high end bracket the measured number.
By their numbers in this assay, from the lowest: compound 1; then compound 3; then compound 4; then compound 2.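

In this assay, for the compounds shown here, the first group without a ring at this position does not fall outside the range set by the aromatic rings: an 11-fold higher number from compound 3 to compound 4 (1.06 log units; beyond the scatter) and a 62-fold higher number from compound 1 to compound 4 (1.79 log units; beyond the scatter), yet a 14-fold lower number from compound 2 to compound 4 (1.14 log units; beyond the scatter). A ring at this place is therefore not needed for a number well below that of compound 2, although neither ring-bearing compound 1 nor compound 3 is matched. All four groups have the same count of heavy atoms, and pyrazin-2-yl and the acyclic group also share their counts of donors and acceptors, so these counts alone do not fix the number.

Nothing available here accounts for these steps. As far as these compounds go, how a plain alkyl chain, an amine or a carboxylic acid would read at this place stays open, as does which part of the acyclic group drives its step.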